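The source may report more compounds than this note shows. Statements on the series, on what has been measured and on what is new or still open speak of the compounds shown alone.

Of the compounds shown here, three sharing one core have been tested in a functional assay on HCT-116 cells (Homo sapiens) for inhibition, read by MTT assay, with a stated time of 2 days, tested at 10 uM; a higher number here means more inhibition of growth at the concentration tested, a lower number less inhibition of growth. Compound 3 `CNC(=O)c1cc(Oc2ccc3nc(NC(=O)c4cc(Cl)cc(Cl)c4)sc3c2)ccn1` gives 13.4% in this assay, the lowest of the three numbers. Compound 1 `CNC(=O)c1cc(Oc2ccc3nc(NC(=O)c4ccc(Cl)cc4Cl)sc3c2)ccn1` gives 15.1%, and the step of a number 1.7 percentage points lower from compound 1 to compound 3 (within the scatter) lies within the scatter. Compound 2 `CNC(=O)c1cc(Oc2ccc3nc(NC(=O)Nc4ccc(C5CCN(C(C)C)CC5)cc4)sc3c2)ccn1` gives 68.1%, a value far beyond the scatter above that of compound 3.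

Compound 4 `CNC(=O)c1cc(Oc2ccc3nc(NC(=O)Nc4ccc(F)cc4)sc3c2)ccn1` has not yet been measured. It differs from compound 3 in one place: (4-fluorophenyl)amino in place of 3,5-dichlorophenyl on a carbonyl carbon. In other words, the amide of compound 3 becomes a urea, as in compound 2.

Within the data shown here, only one measured step changes a single place, and it exchanges one dichlorophenyl for another without leaving the scatter, so it says little about the swap now at hand. What bears more on it is that compound 2, the only urea measured, gives 68.1%, while the two amides sit far lower. Compound 4 carries a different urea partner than compound 2, so a gain of the full distance is not assumed.

For compound 4 an increase is expected, a step of a number 31.6 percentage points higher from compound 3 to compound 4 (beyond the scatter) in this assay. Compound 4 is therefore estimated at 45%, with a range from 20% to 70%.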

Compound 4, percent growth inhibition at one concentration: 12.2%
Compound 4: the middle estimate sits 32.8 percentage points above what was measured, outside the stated range (below it).
By their numbers in this assay, from the lowest: compounds 4, 3 and 1 (each within the scatter of the next); then compound 2.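

In this assay, changing the amide to a urea bearing (4-fluorophenyl)amino does not lift the number on its own (the step is a number 1.2 percentage points lower from compound 3 to compound 4 (within the scatter)), and the comparison with the other amide reads the same way (a number 2.9 percentage points lower from compound 1 to compound 4 (within the scatter)). Among these compounds, then, the urea link alone does not set compound 2 apart, which the earlier compounds could not show while compound 2 was the only urea. With the urea kept and one group exchanged on the aromatic carbon, fluoro in place of 1-isopropylpiperidin-4-yl gives a large change (a number 55.9 percentage points lower from compound 2 to compound 4 (beyond the scatter)), so here the high number goes with the 1-isopropylpiperidin-4-yl group and not with the urea as such.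

Nothing available explains why these steps fall as they do. The compounds shown also leave open which part of the 1-isopropylpiperidin-4-yl group matters, and whether a piperidin-4-yl with a free ring amine, a morpholine or a simple dimethylamino group on that aromatic carbon would give a high number too.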